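Cyano in Place of Methyl on Compound 1

This account rests on a few compounds, and the source may have more. Where it says the series, first, only, none or still open, it means among the compounds named here.

Compound 1 `COC(=O)C1=C(C)N=C(C)/C(=C(/O)OC)C1c1cccc(OCc2c(C)no[n+]2[O-])c1` gives 400 nM in a functional assay (aorta) with Rattus norvegicus as the target, in the presence of a further agent that is not named here; a higher number here means that more compound is needed for the effect, a lower number that less compound is needed. Within the data shown here, that is the highest number of the three measured so far, and it stands beyond the scatter from the other two. Compound 2 `COC(=O)C1=C(C)N=C(C)/C(=C(/O)OC)C1c1ccccc1OCc1c(C)no[n+]1[O-]` gives 78 nM, and compound 3 `COC(=O)C1=C(C)N=C(C)/C(=C(/O)OC)C1c1ccccc1OCc1no[n+]([O-])c1C` gives 43 nM.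

Compound 4 `COC(=O)C1=C(C)N=C(C)/C(=C(/O)OC)C1c1cccc(OCc2c(C#N)no[n+]2[O-])c1` keeps the core of compound 1 and differs from it in a single place: cyano in place of methyl on an aromatic carbon. In short, this is cyano in place of methyl on an aromatic carbon. Among the measured compounds shown here, no measurement yet shows this exchange directly. For the measured compounds named here, the only measured step between compounds that differ in one place is a 1.8-fold lower number from compound 2 to compound 3 (0.26 log units; within the scatter), which lies within the scatter. That step swaps one five-membered aromatic ring group for another with the same atom counts, so it bears on the new change only loosely. It offers no support for a large shift.

In this assay, no step beyond the scatter is therefore expected, although the uncertainty is wide in both directions. The expected step is a 1.6-fold lower number from compound 1 to compound 4 (0.20 log units; within the scatter). For compound 4 the estimated value is 250 nM, with an expected range from 70 nM to 800 nM.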

Compound 4, half-maximal effective concentration: 11 nM
Estimate against measurement, compound 4: 23-fold (1.36 log units) above, outside the stated range (below it).
By their numbers in this assay, from the lowest: compound 4; then compounds 3 and 2 (each within the scatter of the next); then compound 1.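

In this assay, cyano in place of methyl on this aromatic carbon gives a 36-fold lower number from compound 1 to compound 4 (1.56 log units; beyond the scatter), so this place, next to the ring atom that bears a large group, responds strongly to the group it carries. Among these compounds, the only earlier step, a 1.8-fold lower number from compound 2 to compound 3 (0.26 log units; within the scatter), stayed within the scatter and exchanged one ring group for another with the same atom counts. Here, by contrast, a small exchange moves the number well beyond the scatter: methyl gives way to cyano, bringing in a triple bond and 1 hydrogen-bond acceptor, and no measurement given here accounts for the size of this step.

As far as these compounds go, whether the step is particular to cyano stays open, since an ethyl group, a chlorine atom, a carboxamide or a methyl ester on the same aromatic carbon would show how far other groups share it. From the compounds shown here alone, it also remains open whether cyano in place of methyl would give a step of similar size on compound 2 or compound 3, where the ring group is attached differently.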